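Methyl position shift on the aryl-bearing ring carbon

The source may hold more compounds than are shown below. What is called first, only, known or untested is meant among the compounds shown, and "the series" means these compounds.

Compound 1 `CC1=NN(c2cccc(Cl)c2)C(=O)C12C=CC(=O)C=C2c1cccc(C)c1` gives 20100 nM in a functional assay on A549 cells (Homo sapiens) for antiproliferative activity, read by CCK-8 assay, with a stated time of 72 h; on this read-out higher numbers stand for weaker inhibition and lower numbers for stronger inhibition. Compound 2 `CC1=NN(c2ccccc2)C(=O)C12C=CC(=O)C=C2c1cccc(C)c1` gives 16500 nM, and compound 3 `CC1=NN(c2ccc(Cl)cc2)C(=O)C12C=CC(=O)C=C2c1cccc(C)c1` gives 38400 nM. Compound 1 stands second highest of the three numbers; both of its steps stay within the scatter, a 1.2-fold lower number from compound 1 to compound 2 (0.09 log units; within the scatter) and a 1.9-fold higher number from compound 1 to compound 3 (0.28 log units; within the scatter), while a 2.3-fold higher number from compound 2 to compound 3 (0.37 log units; beyond the scatter) is modest but beyond the scatter. Compound 4 `CC1=NN(c2cccc(Cl)c2)C(=O)C12C=CC(=O)C=C2c1ccc(C)cc1` differs from compound 1 by 4-methylphenyl in place of 3-methylphenyl on a double-bonded ring carbon. Within the data shown here, the only measured step of comparable kind, an exchange of 3-chlorophenyl for 4-chlorophenyl, is a 1.9-fold higher number from compound 1 to compound 3 (0.28 log units; within the scatter), which stayed within the scatter; no measured step touches the methylphenyl group itself. A step in this assay no larger than the scatter is therefore expected, in either direction. Compound 4 is estimated at 24000 nM, range 9000 nM to 65000 nM, meaning a 1.2-fold higher number from compound 1 to compound 4 (0.08 log units; within the scatter) is expected.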

Compound 4, half-maximal inhibitory concentration: 9050 nM
Beside the measured number, compound 4's estimate is 2.7-fold (0.42 log units) above it; low and high end bracket the measured number.
By their numbers in this assay, from the lowest: compounds 4, 2, 1 and 3 (each within the scatter of the next, the first and the last beyond it).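

Among these compounds, exchanging 3-methylphenyl for 4-methylphenyl on the double-bonded ring carbon gives the first step at this position, a 2.2-fold lower number from compound 1 to compound 4 (0.35 log units; beyond the scatter). The comparable exchange on the amide-type nitrogen, a 1.9-fold higher number from compound 1 to compound 3 (0.28 log units; within the scatter), stays within the scatter, so the place of the methyl on this ring matters more clearly than the place of the chloro on the other ring, in this single pair.

From the compounds shown here alone, whether a 4-ethylphenyl, a 4-methoxyphenyl or a 4-aminophenyl group at this carbon would follow compound 4 remains open. No measured property accounts for the step.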